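The source may report more compounds than this note shows. Statements on the series, on what has been measured and on what is new or still open speak of the compounds shown alone.

Measured compounds:
compound 1, `CCN(CC)CCn1c(N)c(-c2nc3ccccc3[nH]2)c2nc(C#N)c(C#N)nc21`: 2490 nM
compound 2, `CN(C)CCCn1c(N)c(-c2nc3ccccc3[nH]2)c2nc(C#N)c(C#N)nc21`: 1730 nM
compound 3, `CCN(CC)CCn1c(N)c(-c2nc3ccccc3n2C)c2nc(C#N)c(C#N)nc21`: > 50000 nM (a limit, not a number)

In a functional assay on K562 cells (Homo sapiens) for antiproliferative activity, read by MTT assay, with a stated time of 48 h (on this read-out higher numbers stand for weaker inhibition and lower numbers for stronger inhibition), compound 1 gives 2490 nM. Compound 2 gives 1730 nM in this assay. For compound 3 this assay reports only a limit, > 50000 nM, which sits at the limit of > 50000 nM in this assay, at which 1 of the 3 values shown sits.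

Two changes separate the measured compounds. The first is (dimethylamino)methyl in place of diethylamino on a saturated chain carbon, two bonds along the chain from an aromatic nitrogen; it produced a 1.4-fold lower number from compound 1 to compound 2 (0.16 log units; within the scatter), so compound 1 and compound 2 are treated as equivalent on this read-out. The second is the change by which the core of compound 3 differs from that of compound 1, (methyl in place of hydrogen on an aromatic nitrogen); it produced an at least 20-fold higher number from compound 1 to compound 3 (1.30 log units; beyond the scatter), a large loss that carries compound 3 out of the measurable range.

Compound 4, `CN(C)CCCn1c(N)c(-c2nc3ccccc3n2C)c2nc(C#N)c(C#N)nc21`, has not yet been measured. It carries the core of compound 3 and differs from it by (dimethylamino)methyl in place of diethylamino on a saturated chain carbon, two bonds along the chain from an aromatic nitrogen, the same change as that from compound 1 to compound 2, at a place described in identical words. The expectation for the step from compound 3 to compound 4 is a step that the limit leaves unreadable from compound 3 to compound 4, meaning essentially no movement, resting on the flat step a 1.4-fold lower number from compound 1 to compound 2 (0.16 log units; within the scatter) between compound 1 and compound 2 and on the fact that compound 3 already stands at the limit > 50000 nM. Compound 4 is therefore expected to give about 60000 nM in this assay, most probably again as a limit, within a range of 25000 nM to 200000 nM.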

Compound 4, half-maximal inhibitory concentration: 3560 nM
The estimate for compound 4 lay 17-fold (1.23 log units) above the measured number; measured number below the stated range.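

In this assay the change from diethylamino to (dimethylamino)methyl on a saturated chain carbon does not keep its size from the core of compound 1 to the core of compound 3: it gives an at least 14-fold lower number from compound 3 to compound 4 (1.14 log units; beyond the scatter), and the two steps differ: the same change on two cores in this assay, a 1.4-fold lower number (0.16 log units; within the scatter) from compound 1 to compound 2 and an at least 14-fold lower number (1.14 log units; beyond the scatter) from compound 3 to compound 4, at least 9.7-fold (0.98 log units) apart, beyond the scatter of two such steps

Read the other way, methyl in place of hydrogen on an aromatic nitrogen gives a 2.1-fold higher number from compound 2 to compound 4 (0.31 log units; beyond the scatter) on the 3-(dimethylamino)propyl chain, so in these four compounds the effect of each change depends on the other: the same change on two cores in this assay, an at least 20-fold higher number (1.30 log units; beyond the scatter) from compound 1 to compound 3 and a 2.1-fold higher number (0.31 log units; beyond the scatter) from compound 2 to compound 4, at least 9.7-fold (0.98 log units) apart, beyond the scatter of two such steps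

The value of compound 3, > 50000 nM, is a limit and not a number, so the step from it has a bound but no exact size, and one pair on each core gives neither a rule for other cores nor a cause for this dependence.

Open, as far as these compounds go, is which part of the change matters, the chain length or the groups on the amine, a question that a 2-(dimethylamino)ethyl or a 3-(diethylamino)propyl chain on these cores would address. Also open, from the compounds shown here alone, is how a morpholine at the chain end, or an ethyl in place of the methyl on the aromatic nitrogen, would behave on either core.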